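Compound 2 to compound 4: an added methoxy, expected outcome

A few compounds are considered here, and "the series" means these few. Any claim that something is new, unique, unknown or untested is made for them only; others in the source may bear on it.

Compound 1 `COc1ccc(CN(C(=O)Nc2ccc(Cl)cc2)n2cnnc2)cc1OC` gives 44200 nM in a functional assay on A549 cells (Homo sapiens) for cytotoxicity, read by MTT assay, with a stated time of 48 h; a higher number here means a weaker inhibitor, a lower number a stronger inhibitor. Compound 3 `COc1ccc(CN(C(=O)Nc2ccc(C)cc2)n2cnnc2)cc1OC` gives 22200 nM in this assay. Compound 2 `COc1ccc(CN(C(=O)Nc2ccc(C#N)cc2)n2cnnc2)cc1OC` sits at a limit of this assay, > 50000 nM, so only a floor and no number is known for it (the limit of > 50000 nM in this assay, at which 1 of the 3 values shown sits). The measured steps, an at least 1.1-fold higher number from compound 1 to compound 2 (0.05 log units; that floor lies within the scatter), a 2.0-fold lower number from compound 1 to compound 3 (0.30 log units; within the scatter) and an at least 2.2-fold lower number from compound 2 to compound 3 (0.35 log units; beyond the scatter), all exchange the group on the aromatic carbon of the aniline side. Compound 4 `COc1cc(CN(C(=O)Nc2ccc(C#N)cc2)n2cnnc2)cc(OC)c1OC` differs from compound 2 by methoxy in place of hydrogen on an aromatic carbon. Among the compounds with values here, no measured step touches that part of the core, so none bears directly on this change. The expected step from this change is a step that the limit leaves unreadable from compound 2 to compound 4, none beyond the scatter. For compound 4 the estimate is 60000 nM, with a range from 25000 nM to 150000 nM, and a limit is again likely.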

Compound 4, half-maximal inhibitory concentration: 20700 nM
For compound 4 the middle estimate is 2.9-fold (0.46 log units) above the measured one, and the stated range ends above it.
By their numbers in this assay, from the lowest: compounds 4, 3 and 1 (each within the scatter of the next, the first and the last beyond it). At a limit, above all of these: compound 2.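

The first change away from the aniline side gives an at least 2.4-fold lower number from compound 2 to compound 4 (0.38 log units; beyond the scatter) in this assay. Going by these compounds, compound 2 stands at a limit, > 50000 nM, so this step is only a floor and its full size remains unknown. The added methoxy on the aromatic carbon gives the nitrile member a readable value, with compound 4 at 20700 nM, though this rests on a single pair. On these data alone, whether the same addition gives a comparable step with chloro or methyl on the aniline side remains open. So does the outcome with an amine or a hydroxy group at this position.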